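Taking the Methyl off the Methoxyphenyl Arm

A few compounds are considered here, and "the series" means these few. Any claim that something is new, unique, unknown or untested is made for them only; others in the source may bear on it.

Of the compounds shown here, three sharing one core have been measured in a functional assay on HL-60 cells (Homo sapiens) for cytotoxicity; a higher number here means that more compound is tolerated, a lower number that less compound is tolerated. Compound 1 `COc1cc(/C=C2\Cc3ccccc3/C(=C\c3ccc([N+](=O)[O-])cc3)C2=O)ccc1O` gives 950 nM, compound 2 `COc1cc(/C=C2\Cc3ccccc3/C(=C\c3ccc([N+](=O)[O-])cc3)C2=O)cc(OC)c1OC` gives 550 nM, and compound 3 `COc1ccc(/C=C2\Cc3ccccc3/C(=C\c3ccc([N+](=O)[O-])cc3)C2=O)cc1` gives 4400 nM. Compound 3 therefore stands highest of the three numbers, so more of it is tolerated by the cells than of compound 1 or compound 2, both gaps lying beyond the usual scatter.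

Among the measured compounds shown here, only one pair among the measured compounds differs in a single place: a 4.6-fold higher number from compound 1 to compound 3 (0.67 log units; beyond the scatter), in which a hydroxy-bearing arm gave way to one carrying methoxy alone and the tolerated amount rose. Compound 4 `O=C1/C(=C/c2ccc(O)cc2)Cc2ccccc2/C1=C\c1ccc([N+](=O)[O-])cc1` is now the next candidate. It differs from compound 3 by hydrogen in place of methyl on an oxygen on an aromatic ring, so a hydroxy group now sits where compound 3 carries methoxy.

That move reintroduces a hydroxy group on the same arm, and because a 4.6-fold higher number from compound 1 to compound 3 (0.67 log units; beyond the scatter) showed the number rising when a hydroxy group left that arm, a drop of modest size is expected here, roughly a 2.9-fold lower number from compound 3 to compound 4 (0.47 log units; beyond the scatter). Compound 4 is accordingly estimated at 1500 nM in this assay, with a plausible range from 600 nM to 4000 nM.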

Compound 4, half-maximal cytotoxic concentration: 2500 nM
Compound 4: middle estimate off by 1.7-fold (0.22 log units), on the low side, within the range that was stated.
By their numbers in this assay, from the lowest: compounds 2 and 1 (each within the scatter of the next); then compounds 4 and 3 (each within the scatter of the next).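

On this arm, hydrogen in place of methyl on an oxygen on an aromatic ring gives a 1.8-fold lower number from compound 3 to compound 4 (0.25 log units; within the scatter), so in this assay methoxy and hydroxy at this place cannot be told apart, and compound 3 and compound 4 belong together. The second step, hydrogen in place of methoxy on an aromatic carbon, gives a 2.6-fold higher number from compound 1 to compound 4 (0.42 log units; beyond the scatter), and here the hydroxy group stays on the arm while the number still moves beyond the scatter. Read side by side with a 4.6-fold higher number from compound 1 to compound 3 (0.67 log units; beyond the scatter), this changes the earlier picture: losing the hydroxy group is not needed for the rise, since both arms carrying a single oxygen group, the 4-methoxyphenyl of compound 3 and the 4-hydroxyphenyl of compound 4, stand apart from the 4-hydroxy-3-methoxyphenyl arm of compound 1.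

No measurement at hand explains why these steps fall as they do. On these data alone, whether an amine or a carboxylic acid on this same arm would stay with compound 3 and compound 4, or move the number away from them, remains open, as does the effect of a longer chain such as ethoxy on the oxygen.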